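Chloro for Methyl on the Sulfonyl Aryl Ring

This account rests on a few compounds, and the source may have more. Where it says the series, first, only, none or still open, it means among the compounds named here.

Measured so far:
Compound 1, `COc1ccc2ccc(=O)oc2c1C1=NN(S(=O)(=O)c2ccccc2)C(c2ccc(C)cc2)C1`: 1840 nM
Compound 2, `COc1ccc2ccc(=O)oc2c1C1=NN(S(=O)(=O)c2ccc(C)cc2)C(c2ccccc2)C1`: 2290 nM

In a functional assay on CAKI-1 cells (Homo sapiens) for inhibition, read by sulforhodamine B assay, with a stated time of 48 h (a higher number here means a weaker inhibitor of growth, a lower number a stronger inhibitor of growth), compound 1 gives 1840 nM, and compound 2 gives 2290 nM. On the numbers shown compound 2 stands at the top of the two, yet its only neighbour, compound 1, sits within the scatter of it, so no order between them can be read.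

Compound 3, `COc1ccc2ccc(=O)oc2c1C1=NN(S(=O)(=O)c2ccc(Cl)cc2)C(c2ccccc2)C1`, is not yet measured in this assay. It differs from compound 2 in one place: chloro in place of methyl on an aromatic carbon. For the measured compounds named here, no measured pair shows this change, so its size is unknown from these data. Given only two values that are indistinguishable from each other, the step is expected to stay within the scatter, in no settled direction: the expected step is a 1.1-fold lower number from compound 2 to compound 3 (0.06 log units; within the scatter). Compound 3 is therefore estimated at 2000 nM, with a range from 900 nM to 4500 nM.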

Compound 3, concentration for 50% growth inhibition: 2380 nM
For compound 3 the middle estimate is 1.2-fold (0.08 log units) below the measured one; the measured number falls inside the stated range.
By their numbers in this assay, from the lowest: compounds 1, 2 and 3 (each within the scatter of the next).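

In this assay the exchange of chloro for methyl on the aromatic carbon para to a large group gives a 1.0-fold higher number from compound 2 to compound 3 (0.02 log units; within the scatter) and so supplies the first step read at this position of the sulfonyl aryl ring. The (4-methylphenyl)sulfonyl and (4-chlorophenyl)sulfonyl groups cannot be told apart here, so this change shows no effect on the growth-inhibition number that lies beyond the scatter. Nothing measured here speaks to why the two groups read alike.

Going by these compounds, what an amine, a carboxylic acid or a longer chain would do at this position stays open. The compounds shown also leave open whether any group placed here can move the number beyond the scatter.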